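A few compounds are considered here, and "the series" means these few. Any claim that something is new, unique, unknown or untested is made for them only; others in the source may bear on it.

Compound 3 `CNC(=O)CCc1cn(-c2ccc(Br)cc2)nc1-c1ccc(Cl)cc1` gives < 5000 nM in a physicochemical assay for solubility, in phosphate buffer, measured as thermodynamic solubility, at pH 7.4 (on this read-out higher numbers stand for higher solubility and lower numbers for lower solubility), which is a limit of the assay and not a number. It stands at the limit of < 5000 nM in this assay, at which 1 of the 3 values shown sits. The step to compound 4 `CS(=O)(=O)NC(=O)CCCc1cn(-c2ccc(Br)cc2)nc1-c1ccc(Cl)cc1` is ((methylsulfonyl)carbamoyl)methyl in place of methylcarbamoyl on a saturated chain carbon, two bonds along the chain from an aromatic carbon. Compound 1 `CS(=O)(=O)NC(=O)CCc1cn(-c2ccc(Br)cc2)nc1-c1cccc(Cl)c1` gives 165000 nM and compound 2 `CS(=O)(=O)NC(=O)CCc1cn(-c2ccc(Br)cc2)nc1-c1ccncc1` gives 185000 nM, and both carry a (methylsulfonyl)carbamoyl group, on a shorter chain. Among the measured compounds shown here, the one measured step, a 1.1-fold higher number from compound 1 to compound 2 (0.05 log units; within the scatter), concerns another part of the molecule, so these two values are the only guide. A large upward change is expected, an at least 26-fold higher number from compound 3 to compound 4 (1.41 log units; beyond the scatter). For compound 4 the estimated value is 130000 nM, with an expected range of 40000 nM to 300000 nM.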

Compound 4, solubility: 135000 nM
Beside the measured number, compound 4's estimate is 1.0-fold (0.02 log units) below it; measured number inside the range.
By their numbers in this assay, from the lowest: compounds 4, 1 and 2 (each within the scatter of the next). At a limit, below all of these: compound 3.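

At this saturated chain carbon, two bonds along the chain from an aromatic carbon, ((methylsulfonyl)carbamoyl)methyl in place of methylcarbamoyl gives, in this assay, an at least 27-fold higher number from compound 3 to compound 4 (1.43 log units; beyond the scatter). Among the compounds shown here, the one earlier step, between compound 1 and compound 2, concerned another part of the molecule, so this is the first step that reads on this position. Compound 3 stands at a limit of the assay and not at a number: the limit of < 5000 nM in this assay, at which 1 of the 4 values shown sits.

This change extends the chain and adds the methylsulfonyl part together, so the compounds shown do not separate the two. From the compounds shown here alone, how a carboxylic acid at this place would compare also remains open.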